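From Dimethoxyphenyl to Bromophenyl on the Same Core

The compounds below may be only part of what the source reports. "The series", "measured", "known", "first", "only" and "open" are said of these compounds alone.

For the measured compounds named here, compound 2 `COc1ccc(OC)c(/C=N/NC(=O)Nc2ccc(Oc3ccnc(-c4nncn4CCN(C)C)c3)c(F)c2)c1` stands at the highest of the three numbers so far recorded in a functional assay on HT-29 cells (Homo sapiens) for cytotoxicity, read by MTT assay, with a stated time of 72 h (on this read-out lower numbers stand for stronger inhibition and higher numbers for weaker inhibition), where compound 2 gives 2070 nM. Its nearest neighbour is compound 3 `CN(C)CCn1cnnc1-c1cc(Oc2ccc(NC(=O)N/N=C/c3ccc(F)cc3)cc2F)ccn1`, which in this assay gives 1370 nM; a 1.5-fold lower number from compound 2 to compound 3 (0.18 log units; within the scatter). Furthest away is compound 1 `CN(C)CCn1cnnc1-c1cc(Oc2ccc(NC(=O)N/N=C/c3ccc(Cl)cc3Cl)cc2F)ccn1`, which in this assay gives 390 nM; a 5.3-fold higher number from compound 1 to compound 2 (0.72 log units; beyond the scatter). The remaining measured step is a 3.5-fold higher number from compound 1 to compound 3 (0.55 log units; beyond the scatter).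

Compound 4 `CN(C)CCn1cnnc1-c1cc(Oc2ccc(NC(=O)N/N=C/c3cccc(Br)c3)cc2F)ccn1` is still to be measured in this assay. The change from compound 2 is: 3-bromophenyl in place of 2,5-dimethoxyphenyl on a carbon with a double bond to nitrogen. Going by the values given here, the steps that bear on it are the two that leave the 2,4-dichlorophenyl of compound 1, a 5.3-fold higher number from compound 1 to compound 2 (0.72 log units; beyond the scatter) and a 3.5-fold higher number from compound 1 to compound 3 (0.55 log units; beyond the scatter), which show that a halogen-bearing aryl on a carbon with a double bond to nitrogen gives lower numbers than the 2,5-dimethoxyphenyl. Compound 4 is therefore expected to give about 900 nM in this assay, between 350 nM and 2300 nM. This estimate means a modest downward step of a 2.3-fold lower number from compound 2 to compound 4 (0.36 log units; beyond the scatter).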

Compound 4, half-maximal inhibitory concentration: 380 nM
For compound 4 the middle estimate is 2.4-fold (0.37 log units) above the measured one; measured number inside the range.
By their numbers in this assay, from the lowest: compounds 4 and 1 (each within the scatter of the next); then compounds 3 and 2 (each within the scatter of the next).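

The 3-bromophenyl shows that this position can reach the low numbers of the 2,4-dichlorophenyl with one halogen on the ring: in this assay there is a 5.4-fold lower number from compound 2 to compound 4 (0.74 log units; beyond the scatter), while a 1.0-fold lower number from compound 1 to compound 4 (0.01 log units; within the scatter). A halogen as such does not settle the outcome, since the 4-fluorophenyl of compound 3 goes against that reading, with a 3.6-fold lower number from compound 3 to compound 4 (0.56 log units; beyond the scatter); among these four compounds, only the aryl groups bearing bromine or chlorine give the lower numbers. Nothing given here accounts for this difference between the aryl groups.

The compounds shown leave open whether the halogen or its place on the ring matters more, as a 3-chlorophenyl or a 4-bromophenyl would test. They also leave open how a phenyl carrying an amine or a carboxylic acid would behave here.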